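Swapping Methoxy for Trifluoromethyl on Compound 3

The source may hold more compounds than are shown below. What is called first, only, known or untested is meant among the compounds shown, and "the series" means these compounds.

Measured so far in a functional assay on MKN-45 cells (Homo sapiens) for cytotoxicity, read by MTT assay, with a stated time of 72 h; a lower number here means a stronger inhibitor, a higher number a weaker inhibitor:
Compound 1 `COc1ccc(/C=N/NC(=O)Nc2ccc(Oc3ccnc4cc(OCCCN5CCCCC5)c(OC)cc34)c(F)c2)cc1` gives 660 nM.
Compound 2 `COc1cc2c(Oc3ccc(NC(=O)N/N=C/c4ccc(C(F)(F)F)cc4)cc3F)ccnc2cc1OCCCN1CCCCC1` gives 630 nM.
Compound 3 `COc1ccc(/C=N/NC(=O)Nc2ccc(Oc3ccnc4cc(OCCCN5CCC(C)CC5)c(OC)cc34)c(F)c2)cc1` gives 470 nM.

Compound 3 carries the lowest of the three numbers, but its gap to compound 2 and its gap to compound 1 are both within the usual scatter of repeated measurements, so the three compounds cannot be told apart on these values.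

Compound 4 `COc1cc2c(Oc3ccc(NC(=O)N/N=C/c4ccc(C(F)(F)F)cc4)cc3F)ccnc2cc1OCCCN1CCC(C)CC1` differs from compound 3 in one place: trifluoromethyl in place of methoxy on an aromatic carbon. The same change has already been seen once in this series, between compound 1 and compound 2, where it gave a 1.0-fold lower number from compound 1 to compound 2 (0.02 log units; within the scatter). The other measured step, a 1.4-fold lower number from compound 1 to compound 3 (0.15 log units; within the scatter), concerns the methyl on the saturated ring carbon that compound 3 and compound 4 share, and it too stayed within the scatter. Neither step gives a reason to expect that compound 4 will move away from compound 3 beyond the scatter in this assay. The expected step is therefore a 1.0-fold lower number from compound 3 to compound 4 (0.02 log units; within the scatter). Compound 4 is estimated at 450 nM, with a range from 250 nM to 850 nM.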

Compound 4, half-maximal inhibitory concentration: 1000 nM
Compound 4: the middle estimate sits 2.2-fold (0.35 log units) below what was measured, outside the stated range (above it).
By their numbers in this assay, from the lowest: compounds 3, 2, 1 and 4 (each within the scatter of the next, the first and the last beyond it).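

In this assay, for the compounds shown here, the change from 4-methoxyphenyl to 4-(trifluoromethyl)phenyl gives a 2.1-fold higher number from compound 3 to compound 4 (0.33 log units; beyond the scatter) when the saturated ring carries its methyl, the first step for this change to pass beyond the scatter. That does not show that the two cores respond differently to the change, since the gap between its two steps remains within the scatter: the same change on two cores in this assay, a 1.0-fold lower number (0.02 log units; within the scatter) from compound 1 to compound 2 and a 2.1-fold higher number (0.33 log units; beyond the scatter) from compound 3 to compound 4, 2.2-fold (0.35 log units) apart, within the scatter of two such steps. Adding the methyl to the saturated ring carbon in the trifluoromethyl series gives a 1.6-fold higher number from compound 2 to compound 4 (0.20 log units; within the scatter) and so does not separate these two compounds, and this step also cannot be told apart from the methyl step in the methoxy series: the same change on two cores in this assay, a 1.4-fold lower number (0.15 log units; within the scatter) from compound 1 to compound 3 and a 1.6-fold higher number (0.20 log units; within the scatter) from compound 2 to compound 4, 2.2-fold (0.35 log units) apart, within the scatter of two such steps.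

From the compounds shown here alone, only methoxy and trifluoromethyl appear on this aromatic carbon, so it remains open how a nitrile, a chlorine or a small amine there would read in this assay, and whether a larger set of such groups would show any consistent trend. On the saturated ring carbon only hydrogen and methyl appear, which leaves open what a longer chain or a hydroxyl group at that place would do to either core.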